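Allyl to phenyl on the ring nitrogen: paw edema notes

The source may hold more compounds than are shown below. What is called first, only, known or untested is meant among the compounds shown, and "the series" means these compounds.

Compound 1 `C=CCn1c(SCC(=O)c2ccccc2)nnc1-c1ccccc1` and compound 2 `O=C(CSc1nnc(-c2ccccc2)n1-c1ccccc1)c1ccccc1` share one core; compound 3 `C=CCn1c(SCC(=O)c2ccccc2)nnc1-c1cc(OC)c(OC)c(OC)c1` and compound 4 `COc1cc(-c2nnc(SCC(=O)c3ccccc3)n2-c2ccccc2)cc(OC)c1OC` share another, and the difference between the two cores is not broken down here. In a functional assay on the whole organism (strain albino) for inhibition, with Rattus norvegicus as the target, read by paw edema, with a stated time of 1 h, at a dose of 0.28 mmol/kg by the oral route (on this read-out higher numbers stand for more inhibition at the one dose given (going by the name of the read-out) and lower numbers for less inhibition), compound 1 gives 43%, compound 2 gives 53% and compound 3 gives 49%. The change phenyl in place of allyl on an aromatic nitrogen produced a number 10 percentage points higher from compound 1 to compound 2 (within the scatter). The same kind of change, (phenyl in place of allyl on an aromatic nitrogen), is made on the second core; around the place, compound 3 has next to it a ring atom that bears a (benzoylmethyl)sulfanyl group where compound 1 has one that bears a phenyl group (6 heavy atoms). Compound 4 is expected at 57%, between 42% and 72%. Within the data shown here, the estimated step of a number 8 percentage points higher from compound 3 to compound 4 (within the scatter) is set beside the earlier one because a number 10 percentage points higher from compound 1 to compound 2 (within the scatter) is the single measured instance and lies within the scatter.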

Compound 4, a percentage reported as inhibition, in the whole organism at one dose (the size of the read-out at that dose, not a potency): 44%
The estimate for compound 4 lay 13 percentage points above the measured number; measured number inside the range.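

In this assay, phenyl in place of allyl on the aromatic nitrogen of the second core gives a number 5 percentage points lower from compound 3 to compound 4 (within the scatter). The change does not carry over as a fixed step from one core to the other in this assay: the same change on two cores in this assay, a number 10 percentage points higher (within the scatter) from compound 1 to compound 2 and a number 5 percentage points lower (within the scatter) from compound 3 to compound 4, 15 percentage points apart, beyond the scatter of two such steps. Each step alone lies within the scatter, so neither pair shows that the change raises or lowers inhibition, and two pairs neither show what in the cores sets the gap nor give a rule for other cores.

Open, as far as these compounds go, is how other groups on that nitrogen, such as benzyl or a longer chain like butyl, would read on either core. Also open, from the compounds shown here alone, is whether a carboxylic acid in place of the benzoyl group would alter the gap between the two steps.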